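Compound 3: pyridin-2-yl on the nitrogen of compound 2

The source may report more compounds than this note shows. Statements on the series, on what has been measured and on what is new or still open speak of the compounds shown alone.

In a physicochemical assay for solubility, at pH 7.4 (on this read-out lower numbers stand for lower solubility and higher numbers for higher solubility), compound 1 `CCOc1cc(C)nn1-c1nc(C(F)(F)F)cc(=O)[nH]1` gives 120000 nM and compound 2 `Cc1cc(NCCN(C)C)n(-c2nc(C(F)(F)F)cc(=O)[nH]2)n1` gives 200000 nM. These two values lie within the scatter of each other, so compound 2 stands level with compound 1 and the pair sets no order.

Compound 3 `Cc1cc(Nc2ccccn2)n(-c2nc(C(F)(F)F)cc(=O)[nH]2)n1` keeps the core of compound 2 and differs in one place: pyridin-2-yl in place of 2-(dimethylamino)ethyl on a nitrogen on an aromatic ring. In words, pyridin-2-yl stands in place of 2-(dimethylamino)ethyl on a nitrogen on an aromatic ring, which, cut one bond further out, reads (2-(dimethylamino)ethyl)amino to (pyridin-2-yl)amino.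

Among the compounds with values here, only one measured step bears on this change: a 1.7-fold higher number from compound 1 to compound 2 (0.22 log units; within the scatter), with (2-(dimethylamino)ethyl)amino in place of ethoxy on an aromatic carbon. Within the data shown here, that step stayed within the scatter, but pyridin-2-yl appears in neither compound 1 nor compound 2, so the data offer no direct precedent for it. The direction is therefore a tentative expectation, and the range is kept wide. The expected step is a 2.9-fold lower number from compound 2 to compound 3 (0.46 log units; beyond the scatter). Compound 3 is estimated at 70000 nM, with an expected range of 20000 nM to 200000 nM.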

Compound 3, solubility: 25000 nM
For compound 3 the middle estimate is 2.8-fold (0.45 log units) above the measured one, within the range that was stated.
By their numbers in this assay, from the lowest: compound 3; then compounds 1 and 2 (each within the scatter of the next).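

In this assay the group on this nitrogen now shows a step beyond the scatter: an 8.0-fold lower number from compound 2 to compound 3 (0.90 log units; beyond the scatter) with pyridin-2-yl in place of 2-(dimethylamino)ethyl. The earlier pair gave no such reading, as a 1.7-fold higher number from compound 1 to compound 2 (0.22 log units; within the scatter) stays within the scatter and leaves ethoxy and (2-(dimethylamino)ethyl)amino level on the aromatic carbon. Against the ethoxy compound the new group also separates clearly, with a 4.8-fold lower number from compound 1 to compound 3 (0.68 log units; beyond the scatter) for (pyridin-2-yl)amino in place of ethoxy, which places compound 3 lowest of the series so far, though no measurement on hand accounts for either step.

The compounds shown carry only one aromatic group on this nitrogen, so it stays open whether the lower number goes with an aromatic ring as such or with pyridin-2-yl in particular, a question that a phenyl or pyridin-3-yl group at the same place would address. As far as these compounds go, it also stays open how much of the step follows the loss of the dimethylamino end of the chain, which a morpholine-bearing ethyl chain or a plain ethyl group on this nitrogen would help to separate from the ring.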